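From naphthalen-1-yl to 4-methylphenyl in compound 4

The compounds below may be only part of what the source reports. "The series", "measured", "known", "first", "only" and "open" are said of these compounds alone.

In an ADME assay on HEK-293T cells (Homo sapiens) for inhibition, read by CCK-8 assay, with a stated time of 48 h, tested at 20 uM (a higher number here means more inhibition of growth at the concentration tested, a lower number less inhibition of growth), compound 1 `COc1ccc(S(=O)(=O)Oc2ccccc2/C=C(\C#N)C(=O)Nc2nnc(Cc3cccc4ccccc34)s2)cc1` gives 29% and compound 2 `N#C/C(=C\c1ccccc1OS(=O)(=O)c1ccc([N+](=O)[O-])cc1)C(=O)Nc1nnc(Cc2cccc3ccccc23)s1` gives 25%. Compound 3 `N#C/C(=C\c1ccccc1OS(=O)(=O)c1ccccc1[N+](=O)[O-])C(=O)Nc1nnc(Cc2cccc3ccccc23)s1` has no single number and is recorded only as "not toxic" (no number reported). Compound 4 `Cc1ccc(Cc2nnc(NC(=O)/C(C#N)=C/c3ccccc3OS(=O)(=O)c3ccccc3[N+](=O)[O-])s2)cc1` differs from compound 3 by 4-methylphenyl in place of naphthalen-1-yl on a saturated chain carbon bound to an aromatic carbon, with 4-methylphenyl in place of naphthalen-1-yl on a saturated chain carbon bound to an aromatic carbon. Within the data shown here, the one measured step, a number 4 percentage points lower from compound 1 to compound 2 (within the scatter), lies within the scatter and does not touch this place, so no measured step speaks to the change directly. With compound 2 at 25% as a guide, no step beyond the scatter is expected in this assay. For compound 4 the expected value is 22%, with an estimated range of 5% to 40%.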

Compound 4, percent growth inhibition at one concentration: 6%
Compound 4: middle estimate off by 16 percentage points, on the high side; the measured number falls inside the stated range.
By their numbers in this assay, from the lowest: compound 4; then compounds 2 and 1 (each within the scatter of the next).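

Among these compounds, compound 3 has only the record "not toxic" and no number, so no step from compound 3 to compound 4 can be read. From the compounds shown here alone, what replacing naphthalen-1-yl with 4-methylphenyl does to growth inhibition stays open, and no supporting evidence bears on this result.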